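Swapping a naphthalene for a chlorinated phenyl ring

The source may hold more compounds than are shown below. What is called first, only, known or untested is meant among the compounds shown, and "the series" means these compounds.

Of the compounds shown here, two sharing one core have been measured in a functional assay on HT-29 cells (Homo sapiens) for inhibition, read by MTT assay, with a stated time of 72 h; a lower number here means a stronger inhibitor of growth, a higher number a weaker inhibitor of growth. Compound 1 `O=S(=O)(NCCCNCc1ccccc1Cl)c1cc(C(F)(F)F)cc(C(F)(F)F)c1` gives 20000 nM, and compound 2 `O=S(=O)(NCCCNCc1cccc2ccccc12)c1cc(C(F)(F)F)cc(C(F)(F)F)c1` gives 2600 nM. Within the data shown here, compound 2 therefore holds the lowest number of the two, with compound 1 as its only neighbour at a clearly higher value. Among the measured compounds shown here, the one step measured so far is a 7.7-fold lower number from compound 1 to compound 2 (0.89 log units; beyond the scatter), so replacing 2-chlorophenyl by naphthalen-1-yl brought a modest but real gain.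

Compound 3 `O=S(=O)(NCCCNCc1ccc(Cl)cc1)c1cc(C(F)(F)F)cc(C(F)(F)F)c1` has not been measured. It differs from compound 2 in one place: 4-chlorophenyl in place of naphthalen-1-yl on a saturated chain carbon bound to an amine nitrogen. This change runs the measured step backwards in kind, returning from the two-ring group to a single ring carrying chlorine, though the chlorine now sits at the 4-position rather than the 2-position. For the measured compounds named here, no measured pair shows what that shift of chlorine does on its own, so the only guide is the step from compound 1 to compound 2, which points toward a higher number. Compound 3 is expected to give 12000 nM in this assay, within a range of 4000 nM to 40000 nM, an estimated change of a 4.6-fold higher number from compound 2 to compound 3 (0.66 log units; beyond the scatter).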

Compound 3, concentration for 50% growth inhibition: 2800 nM
Compound 3: the middle estimate sits 4.3-fold (0.63 log units) above what was measured, outside the stated range (below it).
By their numbers in this assay, from the lowest: compounds 2 and 3 (each within the scatter of the next); then compound 1.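

In this assay, the step to 4-chlorophenyl, a 1.1-fold higher number from compound 2 to compound 3 (0.03 log units; within the scatter), shows that a second aromatic ring is not required at this place on a saturated chain carbon bound to an amine nitrogen: a single ring carrying chlorine does as well as naphthalen-1-yl. The other new step, a 7.1-fold lower number from compound 1 to compound 3 (0.85 log units; beyond the scatter), moves only the chlorine, so among these three compounds the higher number goes with 2-chlorophenyl in compound 1 and not with having a single ring, as the first comparison alone might have suggested. Nothing available explains why the chlorine's position on the ring matters or why two such different groups give values within the scatter of each other.

The compounds shown leave open whether the chlorine in 4-chlorophenyl contributes at all, since plain phenyl, 4-fluorophenyl and 4-methoxyphenyl do not appear among them. They also do not show how naphthalen-2-yl compares with naphthalen-1-yl, or whether a longer chain in the shared core would change the picture.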